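A few compounds are considered here, and "the series" means these few. Any claim that something is new, unique, unknown or untested is made for them only; others in the source may bear on it.

Of the compounds shown here, three built on one shared core have been measured in an assay for inhibition of Indoleamine 2,3-dioxygenase 1 (Homo sapiens), read by fluorescence, with a stated time of 1 h; on this read-out higher numbers stand for weaker inhibition and lower numbers for stronger inhibition. Compound 1 `NS(=O)(=O)CC(=O)NCCSc1nonc1/C(=N/O)Nc1cccc(Br)c1` gives 30 nM, compound 3 `NS(=O)(=O)CC(=O)NCCSc1nonc1/C(=N/O)Nc1ccc(F)c(C(F)F)c1` gives 73 nM, and compound 2 `C[C@H](CSc1nonc1/C(=N/O)Nc1ccc(F)c(Br)c1)NC(=O)CS(N)(=O)=O` gives 110 nM. For the measured compounds named here, the one step between compounds differing in a single place, a 2.4-fold higher number from compound 1 to compound 3 (0.39 log units; beyond the scatter), exchanges one ring substituent pattern for another. Compound 2 holds the highest of the three numbers in this assay: its gap to compound 3 lies within the usual scatter, its gap to compound 1 beyond it.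

Going by the values given here, compound 4 `C[C@@H](CSc1nonc1/C(=N/O)Nc1ccc(F)c(Br)c1)NC(=O)CS(N)(=O)=O` has not yet been measured. the two compounds have the same atoms and bonds and differ only in configuration as drawn: 1 of 2 stereo elements differ; a stereocentre at a saturated chain carbon is drawn R in compound 2 and S in compound 4 None of the measured steps bears on this kind of change: the only known step alters a ring substituent, and nothing in the data shows what turning a single stereocentre does to this assay for this core. With no guide available, the step expected from compound 2 to compound 4 is no change at the digits printed from compound 2 to compound 4 (within the scatter), with no settled direction. Compound 4 is therefore estimated at 110 nM in this assay, within a deliberately wide range from 30 nM to 450 nM.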

Compound 4, half-maximal inhibitory concentration: 93 nM
Compound 4: the middle estimate sits 1.2-fold (0.07 log units) above what was measured; low and high end bracket the measured number.
By their numbers in this assay, from the lowest: compound 1; then compounds 3, 4 and 2 (each within the scatter of the next).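

In this assay, drawing the stereocentre at the saturated chain carbon as S instead of R gives a 1.2-fold lower number from compound 2 to compound 4 (0.07 log units; within the scatter), so the two configurations cannot be told apart on this read-out. For the compounds shown here, the comparison speaks to this one stereocentre alone, because nothing else separates the pair: the fact that compounds 2 and 4 differ only in the configuration as drawn The only earlier step concerned a ring substituent, whereas this one shows that, for this pair, the configuration at this carbon keeps the number within the scatter.

On these data alone, what stays open is whether the same holds with another ring substituent pattern on the amine nitrogen, such as the 3-bromophenyl of compound 1. As far as these compounds go, it is also open what an ethyl group, a longer chain or a carboxylic acid would do at this carbon in place of the methyl group.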